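From butylamino to diethylamino on the cyano-bearing ring

A few compounds are considered here, and "the series" means these few. Any claim that something is new, unique, unknown or untested is made for them only; others in the source may bear on it.

Three analogues share one core. In a functional assay on the whole organism with Rattus norvegicus as the target (a lower number here means that less compound is needed, a higher number that more compound is needed for the effect), compound 1 `CCOC(=O)C(=O)Nc1cccc(N(C)C)c1C#N` gives 4.2 mg/kg, compound 2 `CCNc1cccc(NC(=O)C(=O)OCC)c1C#N` gives 0.03 mg/kg, and compound 3 `CCCCNc1cccc(NC(=O)C(=O)OCC)c1C#N` gives 0.3 mg/kg, the second highest of the three numbers, as the step of a 10-fold higher number from compound 2 to compound 3 (1.00 log units; beyond the scatter) and the step of a 14-fold lower number from compound 1 to compound 3 (1.15 log units; beyond the scatter) show. Compound 4 `CCOC(=O)C(=O)Nc1cccc(N(CC)CC)c1C#N` differs from compound 3 in one place: diethylamino in place of butylamino on an aromatic carbon. Among the compounds with values here, the steps that bear on this change run the other way, from dimethylamino to an alkylamino bearing a hydrogen: a 140-fold lower number from compound 1 to compound 2 (2.15 log units; beyond the scatter) and a 14-fold lower number from compound 1 to compound 3 (1.15 log units; beyond the scatter), both large. Since compound 4, like compound 1, carries no hydrogen-bond donor there, a large step upward is expected, a 10-fold higher number from compound 3 to compound 4 (1.00 log units; beyond the scatter). Compound 4 is therefore estimated to give 3 mg/kg, in the range 0.6 mg/kg to 15 mg/kg.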

Compound 4, dose for half-maximal effect: 0.9 mg/kg
For compound 4 the middle estimate is 3.3-fold (0.52 log units) above the measured one, and the stated range covers the measured number.
By their numbers in this assay, from the lowest: compound 2; then compound 3; then compound 4; then compound 1.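

In this assay, the same atoms joined differently still shift the number, with a 3.0-fold higher number from compound 3 to compound 4 (0.48 log units; beyond the scatter), and that step is smaller than a 30-fold higher number from compound 2 to compound 4 (1.48 log units; beyond the scatter), so losing the hydrogen on this nitrogen carries no fixed cost across these compounds. The two compounds without that hydrogen also differ, with a 4.7-fold lower number from compound 1 to compound 4 (0.67 log units; beyond the scatter), so the alkyl groups on this nitrogen matter even without a hydrogen-bond donor. No measurement shown here accounts for these steps. As far as these compounds go, how propylamino or a pyrrolidine ring on this aromatic carbon would compare remains open.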